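Replacing the Diethylamino Chain: an Expected Value for Compound 3

The source may report more compounds than this note shows. Statements on the series, on what has been measured and on what is new or still open speak of the compounds shown alone.

Compound 2 `CCN(CC)CCn1cnnc1-c1cc(Oc2ccc(NC(=O)Nc3ccc(F)c(F)c3)cc2F)ccn1` gives 1240 nM in a functional assay on HT-29 cells (Homo sapiens) for antiproliferative activity, read by MTT assay, with a stated time of 72 h; on this read-out lower numbers stand for stronger inhibition and higher numbers for weaker inhibition. Among the two measured compounds it holds the highest number, with compound 1 `CCN(CC)CCn1cnnc1-c1cc(Oc2ccc(NC(=O)Nc3cccc(C(F)(F)F)c3)cc2F)ccn1` nearest at 630 nM; the step of a 2.0-fold higher number from compound 1 to compound 2 (0.29 log units; within the scatter) lies within the scatter, so the two cannot be ranked against each other. Compound 3 `CN(C)CCCn1cnnc1-c1cc(Oc2ccc(NC(=O)Nc3ccc(F)c(F)c3)cc2F)ccn1` differs from compound 2 at the chain on the shared core: (dimethylamino)methyl in place of diethylamino on a saturated chain carbon, two bonds along the chain from an aromatic nitrogen. Going by the values given here, no measured step touches this place. Among the compounds with values here, the only measured step, from compound 1 to compound 2, alters the group on the amide-type nitrogen and lies within the scatter, so it offers no guide to the amine-bearing chain. With nothing pointing either way, compound 3 is expected to show no change beyond the scatter, and the step of no change at the digits printed from compound 2 to compound 3 (within the scatter) is estimated on that basis. Compound 3 is therefore estimated at 1240 nM in this assay, with a range from 450 nM to 3400 nM.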

Compound 3, half-maximal inhibitory concentration: 1210 nM
Compound 3: the middle estimate sits 1.0-fold (0.01 log units) above what was measured; the measured number falls inside the stated range.
By their numbers in this assay, from the lowest: compounds 1, 3 and 2 (each within the scatter of the next).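

In this assay, going by these compounds alone, replacing the 2-(diethylamino)ethyl chain with 3-(dimethylamino)propyl gives a 1.0-fold lower number from compound 2 to compound 3 (0.01 log units; within the scatter), the first measured step at this position on the shared core. This read-out therefore does not separate these two amine-bearing chains, although the exchange alters both the chain and the groups on its nitrogen. No independent measurement is available to explain this result.

Going by these compounds, it remains open whether a morpholine or a piperidine in place of the dimethylamino group, or a carboxylic acid in place of the amine, would move the number beyond the scatter. It also remains open whether the same chain exchange would read alike with the 3-(trifluoromethyl)phenyl group of compound 1 on the amide-type nitrogen, since the step shown carries the 3,4-difluorophenyl group.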